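The source may hold more compounds than are shown below. What is called first, only, known or untested is meant among the compounds shown, and "the series" means these compounds.

Measured compounds:
- compound 1, `Cc1ccc(S(=O)(=O)NC(=N)N2CCN(c3cc4c(cc3F)c(=O)c(C(=O)O)cn4C3CC3)CC2)cc1`: 71 nM
- compound 2, `CCn1cc(C(=O)O)c(=O)c2cc(F)c(N3CCN(C(=N)NS(=O)(=O)c4ccc(C(F)(F)F)cc4)CC3)cc21`: 71 nM

In a functional assay on A549 cells (Homo sapiens) for antiproliferative activity, read by MTT assay, with a stated time of 72 h (a higher number here means a weaker inhibitor, a lower number a stronger inhibitor), compound 1 gives 71 nM. In the same this assay compound 2 gives 71 nM. These two values match at the digits shown and lie within the scatter of repeated measurements, so the numbers show no difference between compound 1 and compound 2.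

Compound 3, `N=C(NS(=O)(=O)c1ccccc1C(F)(F)F)N1CCN(c2cc3c(cc2F)c(=O)c(C(=O)O)cn3C2CC2)CC1`, has not yet been measured in this assay. It differs from compound 1 in one place: 2-(trifluoromethyl)phenyl in place of 4-methylphenyl on a sulfonyl sulfur. Among the measured compounds shown here, no step between measured compounds isolates this kind of change, so its effect has to be guessed. Compound 1 already sits at a potent level in this assay, and a swap of one aryl group for another on the sulfonyl sulfur is expected to give a step from compound 1 to compound 3 of a 1.2-fold higher number from compound 1 to compound 3 (0.08 log units; within the scatter), that is none beyond the scatter. Compound 3 is therefore expected to give about 85 nM in this assay, within a range from 30 nM to 250 nM.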

Compound 3, half-maximal inhibitory concentration: 71 nM
The estimate for compound 3 lay 1.2-fold (0.08 log units) above the measured number, within the range that was stated.
By their numbers in this assay, from the lowest: compounds 1, 2 and 3 (each within the scatter of the next).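

Among the compounds shown here, putting 2-(trifluoromethyl)phenyl in place of 4-methylphenyl on a sulfonyl sulfur gives, in this assay, no change at the digits printed from compound 1 to compound 3 (within the scatter), so this is the first single-change comparison at this position. For this pair, the sulfonyl sulfur carries a group with more heavy atoms, including fluorine, and a different substituent on the phenyl ring, yet the read-out does not separate the two compounds. No measurement shown here explains why the number stays level.

Both groups are phenyl rings, so the result says nothing about whether a saturated ring such as cyclohexyl or a short alkyl chain such as propyl would keep this level. It also leaves open how a phenyl ring carrying an amine or a carboxylic acid would behave at the same place.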